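Replacing the 4-aminocyclohexyl group of compound 2

A few compounds are considered here, and "the series" means these few. Any claim that something is new, unique, unknown or untested is made for them only; others in the source may bear on it.

In an ADME assay on microsomes from liver (Mus musculus) for metabolic stability, read by LC-MS, using NADPH, with a stated time of 10 min, tested at 10 uM (a lower number here means that the compound disappears faster, a higher number that the compound lasts longer), compound 1 `Nc1ncnc2c1c(Oc1cc(C(F)(F)F)ccn1)nn2[C@H]1CC[C@@H](CO)CC1` gives 0.108 h and compound 2 `Nc1ncnc2c1c(Oc1cc(C(F)(F)F)ccn1)nn2[C@H]1CC[C@@H](N)CC1` gives 0.917 h. The measured move is an 8.5-fold higher number from compound 1 to compound 2 (0.93 log units; beyond the scatter), with amino in place of hydroxymethyl on a saturated ring carbon. Compound 2 therefore holds the higher of these two numbers. Compound 3 `N#Cc1ccnc(Oc2nn([C@H]3C[C@H](O)C3)c3ncnc(N)c23)c1` stands at > 2.41 h, which is a limit of the assay and not a number, and it carries a four-membered non-aromatic ring of carbon only.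

Compound 4 `Nc1ncnc2c1c(Oc1cc(C(F)(F)F)ccn1)nn2[C@H]1C[C@H](F)C1` is reached from compound 2 by one change: 3-fluorocyclobutyl in place of 4-aminocyclohexyl on an aromatic nitrogen. In words, 3-fluorocyclobutyl takes the place of 4-aminocyclohexyl on an aromatic nitrogen. Among the compounds with values here, only one measured step touches this part of the molecule, the substantial move an 8.5-fold higher number from compound 1 to compound 2 (0.93 log units; beyond the scatter), and it kept the six-membered ring that compound 4 gives up. It therefore offers no direct measure of the ring swap. Compound 3, at > 2.41 h, differs from compound 4 in more than one place, so this limit is only a loose hint of a longer half-life. A small rise is therefore expected, not clearly beyond the scatter, and the expected move is a 1.6-fold higher number from compound 2 to compound 4 (0.21 log units; within the scatter). For compound 4 the estimated half-life is 1.5 h, with an expected range from 0.5 h to 3.5 h.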

Compound 4, half-life: 0.883 h
Compound 4: middle estimate off by 1.7-fold (0.23 log units), on the high side; the range from low to high includes it.
By their numbers in this assay, from the lowest: compound 1; then compounds 4 and 2 (each within the scatter of the next). At a limit, above all of these: compound 3.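

In this assay, the change at this aromatic nitrogen from 4-aminocyclohexyl to 3-fluorocyclobutyl gives no readable difference: a 1.0-fold lower number from compound 2 to compound 4 (0.02 log units; within the scatter). The earlier step could have been read as tied to the amino group on a six-membered ring, yet the comparison with the hydroxymethyl compound shows a similar separation with neither that group nor that ring present: an 8.2-fold higher number from compound 1 to compound 4 (0.91 log units; beyond the scatter). This position therefore tolerates a smaller ring of carbon bearing fluorine, with no hydrogen-bond donor in the group, and compounds 2 and 4 stand together, clear of compound 1, in the three compounds that can be compared directly.

Going by these compounds, compound 3 also carries a four-membered ring, but it differs from compound 4 in more than one place and gives a limit of the assay rather than a number: the limit of > 2.41 h in this assay, at which 1 of the 4 values shown sits. What remains open is whether the ring size or the fluorine separates compound 4 from compound 1, and how a carboxylic acid or a methoxy group on the four-membered ring would read in this assay.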